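A piperidine swap on the sulfonyl sulfur of compound 1

A few compounds are considered here, and "the series" means these few. Any claim that something is new, unique, unknown or untested is made for them only; others in the source may bear on it.

In an ADME assay on microsomes (Homo sapiens) for metabolic stability (a lower number here means slower removal, a higher number faster removal of the compound), compound 1 (`CNC(=O)[C@@H]1CCCN1S(=O)(=O)c1ccc(Cl)c(COc2cccc3c(C(F)(F)F)cc(C)nc23)c1Cl`) gives 250 mL/min/kg as its clearance. Compound 2 (`Cc1cc(C(F)(F)F)c2cccc(OCc3c(Cl)ccc(S(=O)(=O)N4CC[C@@H](N(C)C)C4)c3Cl)c2n1`) gives 167 mL/min/kg and compound 3 (`Cc1cc(C(F)(F)F)c2cccc(OCc3c(Cl)ccc(S(=O)(=O)N4CCCCC4)c3Cl)c2n1`) gives 233 mL/min/kg in the same read-out, so compound 1 stands within the scatter of both. Compound 4 (`Cc1cc(C(F)(F)F)c2cccc(OCc3c(Cl)ccc(S(=O)(=O)N4CCC(CCO)CC4)c3Cl)c2n1`) is still unmeasured and keeps the core of compound 1. The change is 4-(2-hydroxyethyl)piperidin-1-yl in place of 2-(methylcarbamoyl)pyrrolidin-1-yl on a sulfonyl sulfur and it is the only one in the structure.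

Three measured steps exchange the group at this same place. The closest guide is compound 3, which carries piperidin-1-yl and is reached by a 1.1-fold lower number from compound 1 to compound 3 (0.03 log units; within the scatter) as the data show. The other two are a 1.5-fold lower number from compound 1 to compound 2 (0.18 log units; within the scatter) and a 1.4-fold higher number from compound 2 to compound 3 (0.14 log units; within the scatter) and neither leaves the scatter. No step beyond the scatter is therefore expected, and the estimated step is a 1.3-fold lower number from compound 1 to compound 4 (0.11 log units; within the scatter) at most in size terms. For compound 4 the estimated clearance is 195 mL/min/kg with an expected range from 115 mL/min/kg to 290 mL/min/kg as the likely span.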

Compound 4, clearance: 367 mL/min/kg
Compound 4: the middle estimate sits 1.9-fold (0.27 log units) below what was measured, and the stated range ends below it.
By their numbers in this assay, from the lowest: compounds 2, 3, 1 and 4 (each within the scatter of the next, the first and the last beyond it).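

Going by these compounds alone, at the sulfonyl sulfur, 4-(2-hydroxyethyl)piperidin-1-yl gives the first step at this place to leave the scatter in this assay, though only a modest one: a 2.2-fold higher number from compound 2 to compound 4 (0.34 log units; beyond the scatter). The other two new steps stay within the scatter, a 1.5-fold higher number from compound 1 to compound 4 (0.17 log units; within the scatter) and a 1.6-fold higher number from compound 3 to compound 4 (0.20 log units; within the scatter), so 2-hydroxyethyl in place of hydrogen on a saturated ring carbon gives no clear change, and none of the three replacements shown leaves the scatter of compound 1. Nothing available here explains these steps.

As far as these compounds go, it remains open whether an amine, a carboxylic acid or a longer chain in place of 2-hydroxyethyl would move clearance beyond the scatter of compound 3. A methoxy group on the same saturated ring carbon is also untested among the compounds shown, so the part played by the hydroxyl group stays unresolved.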